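From 2-methoxyphenyl to benzyl: a small expected step

This account rests on a few compounds, and the source may have more. Where it says the series, first, only, none or still open, it means among the compounds named here.

In a functional assay on T98G cells (Homo sapiens) for inhibition, read by MTT assay, with a stated time of 72 h (on this read-out higher numbers stand for weaker inhibition and lower numbers for stronger inhibition), compound 3 `COc1ccccc1NC(=S)NC1CC(C)(C)Oc2ccc(Br)cc21` gives 42000 nM. That is level with compound 1 `CC1(C)CC(NC(=S)NCc2ccccc2)c2cc(F)ccc2O1` at 40000 nM, whereas compound 2 `CC1(C)CC(NC(=S)Nc2cccc(Cl)c2)c2cc(Br)ccc2O1` gives 9000 nM. The next compound, compound 4 `CC1(C)CC(NC(=S)NCc2ccccc2)c2cc(Br)ccc2O1`, carries benzyl in place of 2-methoxyphenyl on an amide-type nitrogen. For the measured compounds named here, the only measured step at this place is a 4.7-fold higher number from compound 2 to compound 3 (0.67 log units; beyond the scatter), so a change here can move the number. However, that step involved neither benzyl nor a move away from a phenyl group. The closest guide is compound 1, which also carries benzyl on a slightly different core and gives 40000 nM. The expected change is therefore small, a 1.3-fold lower number from compound 3 to compound 4 (0.10 log units; within the scatter), with no shift beyond the scatter anticipated. Compound 4 is estimated at 33000 nM, with an expected range from 13000 nM to 75000 nM.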

Compound 4, half-maximal inhibitory concentration: 54000 nM
Compound 4: the middle estimate sits 1.6-fold (0.21 log units) below what was measured; the range from low to high includes it.
By their numbers in this assay, from the lowest: compound 2; then compounds 1, 3 and 4 (each within the scatter of the next).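

In this assay, benzyl and 2-methoxyphenyl on this nitrogen cannot be told apart, with a 1.3-fold higher number from compound 3 to compound 4 (0.11 log units; within the scatter). The 3-chlorophenyl group alone stands apart so far, with a 6.0-fold higher number from compound 2 to compound 4 (0.78 log units; beyond the scatter), while bromo in place of fluoro on the benzyl compounds also stays within the scatter, with a 1.4-fold higher number from compound 1 to compound 4 (0.13 log units; within the scatter). No measurement available here explains why 3-chlorophenyl differs from the other two groups.

On these data alone, it remains open whether a longer chain, such as phenethyl, or a saturated ring, such as cyclohexyl, on this nitrogen would match benzyl or 3-chlorophenyl. Whether bromo and fluoro would also match when 3-chlorophenyl is present is open too.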